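The compounds below may be only part of what the source reports. "The series", "measured", "known", "first", "only" and "open" are said of these compounds alone.

Working notes on the series. Compound 1 `O=C(Nc1ccccc1)c1ccc(/N=N\c2c[nH]c3ccccc23)cc1` is described in a functional assay on P388 cells (Mus musculus) for inhibition, read by MTT assay, with a stated time of 72 h (on this read-out higher numbers stand for weaker inhibition and lower numbers for stronger inhibition), as "not active" (no number reported), with no number given. Compound 2 `O=C(Nc1cccc(Cl)c1)c1ccc(/N=N\c2c[nH]c3ccccc23)cc1` carries the only numerical result so far: in this assay compound 2 gives 267000 nM, which places it as a weak inhibitor and, on the numbers shown, the single reference point of the set.

Compound 3 `O=C(Nc1ccc(Cl)cc1)c1ccc(/N=N\c2c[nH]c3ccccc23)cc1` has not been measured. Its difference from compound 2 is 4-chlorophenyl in place of 3-chlorophenyl on an amide-type nitrogen. For the measured compounds named here, no step between two measured compounds is available to calibrate this change, so the expectation rests on compound 2 alone; the step from compound 2 to compound 3 is expected to be a 1.2-fold lower number from compound 2 to compound 3 (0.08 log units; within the scatter), that is, none beyond the usual scatter in either direction. Compound 3 is therefore estimated at 220000 nM, with a range from 60000 nM to 800000 nM, and a real chance that only a limit is reported.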

Compound 3, half-maximal inhibitory concentration: 80000 nM
For compound 3 the middle estimate is 2.8-fold (0.44 log units) above the measured one; the range from low to high includes it.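

In this assay, 4-chlorophenyl in place of 3-chlorophenyl on the amide-type nitrogen gives a 3.3-fold lower number from compound 2 to compound 3 (0.52 log units; beyond the scatter) and so shows that this position responds to where the chlorine sits on the phenyl ring, which compound 2 alone could not show. The two groups hold the same atoms joined differently, so the step is a matter of arrangement alone, and it is a modest one resting on a single pair. Nothing measured here bears on what lies behind this step.

Compound 1 carries no number, so the steps from it to the chlorinated compounds cannot be read. Also open, on these data alone, is whether a methoxy group, an amine or a carboxylic acid in place of the chlorine of the 4-chlorophenyl group would carry the number further in either direction.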